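A few compounds are considered here, and "the series" means these few. Any claim that something is new, unique, unknown or untested is made for them only; others in the source may bear on it.

Measured compounds:
compound 1 `CCCCOC(=O)NS(=O)(=O)c1sc(CC(C)C)cc1-c1ccc(Cn2ncnn2)cc1`, which in an assay on membranes from uterus for displacement of a labelled ligand from Angiotensin type II receptor (Sus scrofa), with a stated time of 1.5 h (on this read-out higher numbers stand for weaker inhibition and lower numbers for stronger inhibition), gives 16 nM;
compound 2 `CCCCOC(=O)NS(=O)(=O)c1sc(CC(C)C)cc1-c1ccc(C(=O)c2ccnn2C)cc1`, which in this assay gives 3.4 nM.

Within the data shown here, compound 2 stands at the lowest of the two numbers, and the only measured step, a 4.7-fold lower number from compound 1 to compound 2 (0.67 log units; beyond the scatter), separates it from its single neighbour. Compound 3 `CCCCOC(=O)NS(=O)(=O)c1sc(CC(C)C)cc1-c1ccc(C(=O)c2cccs2)cc1` differs from compound 2 by thiophen-2-yl in place of 1-methyl-1H-pyrazol-5-yl on a carbonyl carbon. Among the measured compounds shown here, no measured step bears on this change directly: the one step known alters the group on the aromatic carbon, not the ring on the carbonyl carbon, so it shows only that the arrangement at that position can move the number by a modest amount. With the carbonyl kept and one five-membered aromatic ring exchanged for another, the step of a 1.3-fold higher number from compound 2 to compound 3 (0.12 log units; within the scatter) is expected to stay small, with no direction beyond the scatter. Compound 3 is therefore estimated at 4.5 nM, within a range from 1.5 nM to 14 nM.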

Compound 3, inhibition constant: 18.8 nM
Compound 3: middle estimate off by 4.2-fold (0.62 log units), on the low side, and the stated range ends below it.
By their numbers in this assay, from the lowest: compound 2; then compounds 1 and 3 (each within the scatter of the next).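

In this assay, the ring on the carbonyl carbon proves to matter: with the carbonyl kept, thiophen-2-yl in place of 1-methyl-1H-pyrazol-5-yl gives a step beyond the scatter (a 5.5-fold higher number from compound 2 to compound 3 (0.74 log units; beyond the scatter)). The carbonyl alone therefore does not set these compounds apart from the compound carrying (2H-tetrazol-2-yl)methyl, as the (thiophen-2-yl)carbonyl group reads level with that group (a 1.2-fold higher number from compound 1 to compound 3 (0.07 log units; within the scatter)). Nothing measured here accounts for the difference between the two rings.

The compounds shown leave open whether the methyl group or the ring nitrogens of 1-methyl-1H-pyrazol-5-yl carry the difference, as the two rings differ in both at once. As far as these compounds go, how a plain phenyl ring, or a pyrazole ring without the methyl group, would read on the carbonyl carbon also remains open.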